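The source may hold more compounds than are shown below. What is called first, only, known or untested is meant among the compounds shown, and "the series" means these compounds.

In a functional assay on A549 cells (Homo sapiens) for cytotoxicity, read by MTT assay, with a stated time of 72 h (on this read-out higher numbers stand for weaker inhibition and lower numbers for stronger inhibition), compound 1 (`COc1ccc(/C=N/NC(=O)Nc2cc3c(Nc4ccc(F)c(Cl)c4)ncnc3cc2O[C@H]2CCOC2)cc1`) gives 33100 nM and compound 2 (`COc1cc(/C=N/NC(=O)Nc2cc3c(Nc4ccc(F)c(Cl)c4)ncnc3cc2O[C@H]2CCOC2)cc(OC)c1OC`) gives 26400 nM. Within the data shown here, these two numbers lie within the scatter of each other, so compound 2 stands level with the only other compound measured. Compound 3 (`O=C(N/N=C/c1ccc(O)cc1O)Nc1cc2c(Nc3ccc(F)c(Cl)c3)ncnc2cc1O[C@H]1CCOC1`) carries 2,4-dihydroxyphenyl in place of 3,4,5-trimethoxyphenyl on a carbon with a double bond to nitrogen. Among the measured compounds shown here, only one measured step bears on this change, a 1.3-fold lower number from compound 1 to compound 2 (0.10 log units; within the scatter), which exchanges 4-methoxyphenyl for 3,4,5-trimethoxyphenyl at that same place and stays within the scatter. For the measured compounds named here, no measured compound carries 2,4-dihydroxyphenyl, so this evidence is indirect. A step beyond the scatter is therefore not expected in this assay, in either direction. The expected size of the change is a 1.2-fold lower number from compound 2 to compound 3 (0.08 log units; within the scatter). For compound 3 the estimated value is 22000 nM, with an expected range from 7000 nM to 50000 nM.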

Compound 3, half-maximal inhibitory concentration: 9360 nM
Estimate against measurement, compound 3: 2.4-fold (0.37 log units) above, within the range that was stated.
By their numbers in this assay, from the lowest: compound 3; then compounds 2 and 1 (each within the scatter of the next).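

At the carbon with a double bond to nitrogen, 2,4-dihydroxyphenyl in place of 3,4,5-trimethoxyphenyl gives in this assay a step beyond the scatter (a 2.8-fold lower number from compound 2 to compound 3 (0.45 log units; beyond the scatter)), and 2,4-dihydroxyphenyl in place of 4-methoxyphenyl gives another (a 3.5-fold lower number from compound 1 to compound 3 (0.55 log units; beyond the scatter)). The earlier pair had stayed within the scatter, so only now does this position respond to the group it carries, and compound 3 has the lowest number of the three, with both of its steps beyond the scatter. Nothing available here explains these steps.

On these data alone, whether a single hydroxyl group, as in 4-hydroxyphenyl, would be enough remains open. So does whether a phenyl ring carrying an amine or a carboxylic acid at this place would stand with compound 3 or with compound 1 and compound 2.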